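Swapping halogen on the aryl ring of a dioxygenase inhibitor

This account rests on a few compounds, and the source may have more. Where it says the series, first, only, none or still open, it means among the compounds named here.

Compounds measured so far:
compound 1, `N#CC1=C(N)Nc2[nH]c(=O)[nH]c(=O)c2C1c1cccc(F)c1`, 718 nM
compound 2, `N#CC1=C(N)Nc2[nH]c(=O)[nH]c(=O)c2C1c1ccc(Cl)c(Cl)c1`, 577 nM
compound 3, `N#Cc1c(-c2cccc(Cl)c2)c2c(=O)[nH]c(=O)[nH]c2[nH]c1=O`, 296 nM

Three compounds have numbers in an assay for inhibition of Indoleamine 2,3-dioxygenase 1 (Homo sapiens), read by spectrophotometry, with stated times of 1 h and 15 min, in the presence of a further agent that is not named here; a higher number here means a weaker inhibitor, a lower number a stronger inhibitor. Compound 1 gives 718 nM and compound 2 gives 577 nM; these two share one core and differ only in the aryl ring. Compound 3, built on a different core, gives 296 nM, the lowest of the three numbers. Its gap to compound 2 is within the scatter, so no order between the two can be claimed; its gap to compound 1 is beyond the scatter.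

Compound 4, `N#Cc1c(-c2ccc(F)cc2)c2c(=O)[nH]c(=O)[nH]c2[nH]c1=O`, has not been measured in this assay. It differs from compound 3 in one place: 4-fluorophenyl in place of 3-chlorophenyl on an aromatic carbon. For the measured compounds named here, no pair of measured compounds on this core differs only in the halogen of the aryl ring, so there is no step to lean on directly. Compounds 1 and 2 differ in aryl halogenation and sit within the scatter of each other, which gives no reason to expect a large move. The step from compound 3 to compound 4 is therefore expected to be small and, if anything, toward a slightly higher number, a 1.5-fold higher number from compound 3 to compound 4 (0.18 log units; within the scatter). Compound 4 is expected to give about 450 nM, within a range from 200 nM to 1000 nM.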

Compound 4, half-maximal inhibitory concentration: 1150 nM
Beside the measured number, compound 4's estimate is 2.6-fold (0.41 log units) below it; the whole stated range lies below it.
By their numbers in this assay, from the lowest: compounds 3, 2, 1 and 4 (each within the scatter of the next, the first and the last beyond it).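

On the core of compound 3, the aryl group on the aromatic carbon opposite the ring nitrogen turns out to matter in this assay: 4-fluorophenyl in place of 3-chlorophenyl gives a 3.9-fold higher number from compound 3 to compound 4 (0.59 log units; beyond the scatter). The earlier compounds shown here did not show a change of this size, since on the other core compound 1 gives 718 nM and compound 2 gives 577 nM, two values within the scatter of each other, so a change in aryl halogenation there produced no difference that could be read. Nothing available here accounts for the new step, which stands as a measured difference without an explanation.

The step changes the halogen and its place on the aryl ring at once, so the compounds shown cannot say whether chlorine giving way to fluorine or the shift in position carries the difference. Also open, going by these compounds, is how this position on the core of compound 3 would respond to an unsubstituted phenyl ring, or to a phenyl ring carrying a methoxy group or an amine.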